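Acetyl Added to an Ether Scaffold Sitting at the Limit

This account rests on a few compounds, and the source may have more. Where it says the series, first, only, none or still open, it means among the compounds named here.

Compound 2 `Cc1ccccc1C(CCC(=O)O)Oc1cccc(OCc2ccsc2)c1` was examined in an assay on cerebellum for binding affinity to Endothelin receptor type B (Rattus norvegicus); on this read-out higher numbers stand for weaker inhibition and lower numbers for stronger inhibition. In this assay compound 2 gives > 30000 nM, a limit of the assay rather than a number. Compound 1 `Cc1ccccc1C(CCC(=O)O)C(=O)c1cccc(OCc2ccsc2)c1` likewise gives a limit in this assay, > 30000 nM. Among the compounds with values here, both values rest at the limit of > 30000 nM in this assay, at which 2 of the 2 values shown sit, so no measured step between them can be stated. Compound 3 `CC(=O)c1ccc(OCc2ccsc2)cc1OC(CCC(=O)O)c1ccccc1C` differs from compound 2 by acetyl in place of hydrogen on an aromatic carbon. With nothing measured to guide the direction, the step is expected to be an at least 1.5-fold lower number from compound 2 to compound 3 (0.17 log units; that floor lies within the scatter), not clearly beyond the scatter. For compound 3 the estimate in this assay is 20000 nM, within 2000 nM to 100000 nM.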

Compound 3, half-maximal inhibitory concentration: 10000 nM
Beside the measured number, compound 3's estimate is 2.0-fold (0.30 log units) above it, and the stated range covers the measured number.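

Acetyl on this aromatic carbon, ortho to a large group and para to a (thiophen-3-yl)methoxy group, gives the first readable step in this assay: an at least 3.0-fold lower number from compound 2 to compound 3 (0.47 log units; beyond the scatter). Compound 3 is thus the only one of the three with a value that is a number rather than a limit, so this position is one where a change can register. The step is only a floor, because its starting value is a limit: the limit of > 30000 nM in this assay, at which 2 of the 3 values shown sit.

As far as these compounds go, it remains open whether methyl, an amine or a carboxylic acid on this same carbon would give a comparable step. From the compounds shown here alone, it is also open whether acetyl would have the same effect on the core of compound 1.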